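The source may hold more compounds than are shown below. What is called first, only, known or untested is meant among the compounds shown, and "the series" means these compounds.

For the measured compounds named here, compound 3 `O[C@H](COCCOC[C@@H](O)Cc1cn(Cc2ccc(C(F)(F)F)cc2)nn1)Cc1ccc(-c2ccccc2)cc1` gives 2500 nM in a functional assay on HCT-116 cells (Homo sapiens) for inhibition, read by MTT assay, with a stated time of 72 h (a lower number here means a stronger inhibitor of growth, a higher number a weaker inhibitor of growth), the lowest of the three numbers measured so far. Compound 1 `O[C@H](COCCOC[C@@H](O)Cc1cn(Cc2ccc(Oc3ccccc3)cc2)nn1)Cc1ccc(-c2ccccc2)cc1` gives 3400 nM, and the step of a 1.4-fold lower number from compound 1 to compound 3 (0.13 log units; within the scatter). Compound 2 `O[C@H](COCCOC[C@@H](O)Cc1cn(-c2ccc3c(c2)OCCO3)nn1)Cc1ccc(-c2ccccc2)cc1` gives 16500 nM, and the step of a 6.6-fold lower number from compound 2 to compound 3 (0.82 log units; beyond the scatter). Compound 4 `O[C@H](COCCOC[C@@H](O)Cc1cn(-c2cncc3ccccc23)nn1)Cc1ccc(-c2ccccc2)cc1` differs from compound 3 in one place: isoquinolin-4-yl in place of 4-(trifluoromethyl)benzyl on an aromatic nitrogen. The step between compound 2 and compound 3 bears on this change, since compound 2 also carries a ring on the aromatic nitrogen rather than a benzyl group; that step was modest and beyond the scatter, and compound 4 reverses its direction, so a higher number of similar size is expected. Compound 4 is therefore expected to give 10000 nM, within 3000 nM to 30000 nM, an expected step of a 4.0-fold higher number from compound 3 to compound 4 (0.60 log units; beyond the scatter).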

Compound 4, concentration for 50% growth inhibition: 17800 nM
Compound 4: middle estimate off by 1.8-fold (0.25 log units), on the low side; the range from low to high includes it.
By their numbers in this assay, from the lowest: compounds 3 and 1 (each within the scatter of the next); then compounds 2 and 4 (each within the scatter of the next).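

In this assay, isoquinolin-4-yl in place of 4-(trifluoromethyl)benzyl on the aromatic nitrogen gives a 7.1-fold higher number from compound 3 to compound 4 (0.85 log units; beyond the scatter), so a second ring group without a benzyl link falls with compound 2, not with compound 3. The step of a 1.1-fold higher number from compound 2 to compound 4 (0.03 log units; within the scatter) leaves isoquinolin-4-yl and 2,3-dihydro-1,4-benzodioxin-6-yl indistinguishable here. Nothing available explains this gap.

On these data alone, it remains open whether the link or the ring substituents matter more. An isoquinolin-4-ylmethyl group, or a longer chain such as phenethyl, on that nitrogen would separate them.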